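Flipping Two Ring Stereocentres in a Dimeric Carbamate Scaffold

A few compounds are considered here, and "the series" means these few. Any claim that something is new, unique, unknown or untested is made for them only; others in the source may bear on it.

Of the compounds shown here, two have been measured in an ADME assay on the whole organism for pharmacokinetics, with Rattus norvegicus as the target, at a dose of 3 mg/kg by the oral route; on this read-out higher numbers stand for higher oral bioavailability and lower numbers for lower oral bioavailability. Compound 1 `COC(=O)N[C@H](C(=O)N1CCC[C@H]1C(=O)Nc1ccc([C@H]2CC[C@H](c3ccc(NC(=O)[C@@H]4CCCN4C(=O)[C@@H](NC(=O)OC)[C@@H](C)OC)cc3)N2c2ccc(F)cc2)cc1)[C@@H](C)OC` gives 15%, while compound 2 `COC(=O)N[C@H](C(=O)N1CCC[C@H]1C(=O)Nc1ccc([C@@H]2CC[C@@H](c3ccc(NC(=O)[C@@H]4CCCN4C(=O)[C@@H](NC(=O)OC)[C@H]4CCOC4)cc3)N2c2ccc(F)cc2)cc1)[C@H]1CCOC1` gives 1.5%. Compound 2 thus stands lowest of the two numbers, and its nearest neighbour compound 1 sits higher by a margin that is beyond the scatter.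

Compound 3 `COC(=O)N[C@H](C(=O)N1CCC[C@H]1C(=O)Nc1ccc([C@H]2CC[C@H](c3ccc(NC(=O)[C@@H]4CCCN4C(=O)[C@@H](NC(=O)OC)[C@H]4CCOC4)cc3)N2c2ccc(F)cc2)cc1)[C@H]1CCOC1` is a new member of the set. Compared with compound 2, it changes as follows: the two compounds have the same atoms and bonds and differ only in configuration as drawn: 2 of 8 stereo elements differ; a stereocentre at a saturated ring carbon is drawn S in compound 2 and R in compound 3; a stereocentre at a saturated ring carbon is drawn S in compound 2 and R in compound 3. Within the data shown here, no pair of measured compounds differs in this way, so there is no directly comparable step to lean on. With the same atoms and bonds in place, the expectation for this assay is a modest change, most likely no further than the usual scatter, with a slight lean upward. Compound 3 is therefore estimated at 6%, within a range of 1% to 18%, which means an expected step of a number 4.5 percentage points higher from compound 2 to compound 3 (within the scatter).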

Compound 3, oral bioavailability in the Rattus norvegicus assay: 3.2%
Beside the measured number, compound 3's estimate is 2.8 percentage points above it, within the range that was stated.
By their numbers in the Rattus norvegicus assay, from the lowest: compounds 2 and 3 (each within the scatter of the next); then compound 1.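

Among these compounds, in the Rattus norvegicus assay compound 2 gives 1.5% and compound 3 gives 3.2%, and drawing both stereocentres at the saturated ring carbons as R instead of S amounts to a number 1.7 percentage points higher from compound 2 to compound 3 (within the scatter), so this read-out does not tell the two configurations apart, something the earlier compounds could not show. In a physicochemical assay for solubility, in phosphate buffer, measured as kinetic solubility, at pH 7.2 (a higher number here means a more soluble compound, a lower number a less soluble compound), the picture is the same: compound 2 gives 9700 nM and compound 3 gives 8500 nM, which amounts to a 1.1-fold lower number from compound 2 to compound 3 (0.06 log units; within the scatter). Among the compounds shown here, this pair gives the first reading of a single kind of change, as nothing else in the structure varies: the fact that compounds 2 and 3 differ only in the configuration as drawn.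

The compounds shown leave open whether the same flip of the two ring carbons would also make so little difference in compound 1, whose side chains are different. They also leave open how either configuration would read with a different group on the shared core, such as an amine in place of the fluorine.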